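Replacing the urea end group with a hydroxy acid amide

A few compounds are considered here, and "the series" means these few. Any claim that something is new, unique, unknown or untested is made for them only; others in the source may bear on it.

Measured so far:
Compound 1 `CNCC(=O)NC[C@@H]1CCCc2cc(S(=O)(=O)c3cccc(F)c3)ccc21` gives 0.159 nM in an assay on isolated protein for displacement of a labelled ligand from 5-hydroxytryptamine receptor 6 (Homo sapiens); a higher number here means a weaker inhibitor, a lower number a stronger inhibitor.
Compound 2 `CN(C)C(=O)NC[C@@H]1CCCc2cc(S(=O)(=O)c3cccc(F)c3)ccc21` gives 2.51 nM in this assay.

Among the two measured compounds, compound 2 has the higher number, so it is the weaker binder of the pair. Going by the values given here, the one measured step, a 16-fold higher number from compound 1 to compound 2 (1.20 log units; beyond the scatter), is large and well beyond the scatter; it arose from dimethylamino in place of (methylamino)methyl on a carbonyl carbon. That single comparison shows that the group on this carbonyl carbon strongly affects the result.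

Compound 3 `CC(C)(O)C(=O)NC[C@@H]1CCCc2cc(S(=O)(=O)c3cccc(F)c3)ccc21` differs from compound 2 in just that spot: 1-hydroxy-1-methylethyl in place of dimethylamino on a carbonyl carbon. The entering group, like the group in compound 1, is joined to the carbonyl through carbon and carries one hydrogen-bond donor, whereas dimethylamino in compound 2 carries none. On that basis the step of a 4.2-fold lower number from compound 2 to compound 3 (0.62 log units; beyond the scatter) is expected to run downward in this assay, undoing part but likely not all of the loss seen in a 16-fold higher number from compound 1 to compound 2 (1.20 log units; beyond the scatter). Compound 3 is therefore estimated at 0.6 nM, with a plausible range from 0.2 nM to 2.5 nM.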

Compound 3, inhibition constant: 2 nM
For compound 3 the middle estimate is 3.3-fold (0.52 log units) below the measured one; the range from low to high includes it.
By their numbers in this assay, from the lowest: compound 1; then compounds 3 and 2 (each within the scatter of the next).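

Swapping dimethylamino for 1-hydroxy-1-methylethyl on this carbonyl carbon makes no readable difference in this assay: the result is a 1.3-fold lower number from compound 2 to compound 3 (0.10 log units; within the scatter). The entering group carries 1 hydrogen-bond donor and dimethylamino carries 0, so in this pair, adding that donor and changing the atom joined to the carbonyl from nitrogen to carbon do not separate the two compounds. The large gap to the best compound remains, at a 13-fold higher number from compound 1 to compound 3 (1.10 log units; beyond the scatter), so among these three end groups only the (methylamino)methyl of compound 1 stands apart, and no data here explain why.

The compounds shown leave open which feature of (methylamino)methyl goes with the low number of compound 1, since its nitrogen, its hydrogen and its chain have not been separated from one another here. Placing an aminomethyl, a dimethylaminomethyl or a hydroxymethyl group on the same carbonyl carbon would test these features one at a time, and a longer chain such as 2-(methylamino)ethyl would show whether the distance of that nitrogen from the carbonyl matters.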